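Swapping the pendant aryl ring: from chloro to methoxy

The source may report more compounds than this note shows. Statements on the series, on what has been measured and on what is new or still open speak of the compounds shown alone.

Of the compounds shown here, three sharing one core have been tested in a functional assay on A549 cells (Homo sapiens) for antiproliferative activity, read by MTT assay, with a stated time of 72 h; a lower number here means a stronger inhibitor, a higher number a weaker inhibitor. Compound 1 `COc1cc(-n2cnc3ccc(-c4ccc(C(F)(F)F)cc4)cc32)cc(OC)c1OC` gives 3390 nM. Compound 2 `COc1cc(-n2cnc3ccc(-c4cccc(Cl)c4)cc32)cc(OC)c1OC` gives 7050 nM, the highest of the two numbers recorded, and the step of a 2.1-fold higher number from compound 1 to compound 2 (0.32 log units; beyond the scatter) lies beyond the scatter. Compound 3 `COc1cc(-c2ccc3ncn(-c4cc(OC)c(OC)c(OC)c4)c3c2)cc(OC)c1OC` reaches only (the limit of > 10000 nM in this assay, at which 1 of the 3 values shown sits), so for compound 3 the result > 10000 nM is a limit of the assay rather than a number.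

The next compound, compound 4 `COc1ccc(-c2ccc3ncn(-c4cc(OC)c(OC)c(OC)c4)c3c2)cc1`, differs from compound 2 in one place: 4-methoxyphenyl in place of 3-chlorophenyl on an aromatic carbon. Among the compounds with values here, only one measured step concerns this pendant ring, the change from compound 1 to compound 2, and it was modest. Within the data shown here, compound 3 carries a trimethoxyphenyl at the same place and gave only a limit, which hints that crowding this ring with methoxy groups does not help, but no step to compound 4 is available from it. A single methoxy is expected to sit somewhere between these outcomes, so a modest weakening beyond the scatter is estimated, a 1.3-fold higher number from compound 2 to compound 4 (0.11 log units; within the scatter). For compound 4 the expected value in this assay is 9000 nM, with a range from 3500 nM to 20000 nM.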

Compound 4, half-maximal inhibitory concentration: > 10000 nM
Compound 4 gave a limit, no number; the forecaster's own chance of this, stated with the estimate: 35%; middle value at least 1.1-fold (0.04 log units) away from the limit.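

A single methoxy on the pendant ring is enough to lose a measurable result: in this assay compound 4 gives > 10000 nM, which is a limit and not a number. Within the data shown here, measured against the 3-chlorophenyl ring, the change is an at least 1.4-fold higher number from compound 2 to compound 4 (0.15 log units; that floor lies within the scatter), and since that floor lies within the scatter, this comparison alone settles little; the clearer reading comes from 4-methoxyphenyl replacing 4-(trifluoromethyl)phenyl, which gives an at least 2.9-fold higher number from compound 1 to compound 4 (0.46 log units; beyond the scatter), the first step to a methoxy-bearing ring that passes the scatter. Among these four compounds, both rings carrying methoxy, in compound 3 and compound 4, now end at the same ceiling, while the chloro and trifluoromethyl rings of compound 2 and compound 1 give numbers, with no compound here going against that split: the limit of > 10000 nM in this assay, at which 2 of the 4 values shown sit.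

Any step between compound 3 and compound 4 cannot be read, since neither has a number, so how much weaker either one is remains unknown. From the compounds shown here alone, it also remains open whether a methoxy at the 3 position of the ring would behave like the 4-methoxyphenyl group, and whether an amine or a carboxylic acid on this ring would give a lower number than compound 1.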